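From isopentyl to (tert-butyl)carbonyl on the shared core

This account rests on a few compounds, and the source may have more. Where it says the series, first, only, none or still open, it means among the compounds named here.

Measured in a functional assay on A549 cells (Homo sapiens) for cytotoxicity, with a stated time of 48 h; a higher number here means a weaker inhibitor, a lower number a stronger inhibitor:
- compound 1 `CC(C)CC(=O)Oc1ccc2oc(/C=C/[S+](C)[O-])cc(=O)c2c1`: 2300 nM
- compound 2 `CCCCC(=O)Oc1ccc2oc(/C=C/[S+](C)[O-])cc(=O)c2c1`: 2400 nM
- compound 3 `CC(C)CCOc1ccc2oc(/C=C/[S+](C)[O-])cc(=O)c2c1`: 1000 nM

Compound 3 has the lowest number of the three at 1000 nM, making it the strongest inhibitor so far. The next structure, compound 4 `C[S+]([O-])/C=C/c1cc(=O)c2cc(OC(=O)C(C)(C)C)ccc2o1`, differs from it by (tert-butyl)carbonyl in place of isopentyl on an oxygen on an aromatic ring. The closest evidence runs the opposite way, from a carbonyl-bearing chain to isopentyl: a 2.3-fold lower number from compound 1 to compound 3 (0.36 log units; beyond the scatter) and a 2.4-fold lower number from compound 2 to compound 3 (0.38 log units; beyond the scatter), both modest. Changing the chain beyond the carbonyl gave a 1.0-fold higher number from compound 1 to compound 2 (0.02 log units; within the scatter). Among the measured compounds shown here, no measured compound carries the (tert-butyl)carbonyl, so some uncertainty remains. The expected change is a similarly modest rise, a 2.3-fold higher number from compound 3 to compound 4 (0.36 log units; beyond the scatter). Compound 4 is estimated at 2300 nM, with an expected range of 1000 nM to 5000 nM.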

Compound 4, half-maximal inhibitory concentration: 1600 nM
Compound 4: the middle estimate sits 1.4-fold (0.16 log units) above what was measured; the range from low to high includes it.
By their numbers in this assay, from the lowest: compounds 3, 4, 1 and 2 (each within the scatter of the next, the first and the last beyond it).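

In this assay, (tert-butyl)carbonyl in place of isopentyl on this oxygen gives a 1.6-fold higher number from compound 3 to compound 4 (0.20 log units; within the scatter), so this carbonyl-bearing group cannot be told apart from isopentyl, although the groups on compound 1 and compound 2 could be. Among the carbonyl-bearing groups, the shape of the chain separates nothing either: tert-butyl in place of butyl gives a 1.5-fold lower number from compound 2 to compound 4 (0.18 log units; within the scatter), and tert-butyl in place of isobutyl gives a 1.4-fold lower number from compound 1 to compound 4 (0.16 log units; within the scatter). Nothing available explains these results. 

Still open, on these data alone, is how an amine, a carboxylic acid or a longer chain on this oxygen would read in this assay.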